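The source may hold more compounds than are shown below. What is called first, only, known or untested is meant among the compounds shown, and "the series" means these compounds.

- Compound 1 `O=C(CCCCCn1cc(Nc2ncc(Cl)c(Nc3cccc(Cl)c3)n2)cn1)NO`: 580 nM
- Compound 2 `O=C(CCCCCn1cc(Nc2ncc(Cl)c(Nc3ccc(F)cc3)n2)cn1)NO`: 420 nM
- Compound 3 `O=C(CCCCCn1cc(Nc2ncc(Cl)c(Nc3ccc(Cl)cc3)n2)cn1)NO`: 490 nM

All three values come from a functional assay on K562 cells (Homo sapiens) for antiproliferative activity, read by MTT assay, with a stated time of 48 h; on this read-out higher numbers stand for weaker inhibition and lower numbers for stronger inhibition. Compound 3 lies within the scatter of both other compounds, so the three cannot be ranked on these numbers. Compound 4 `O=C(CCCCCn1cc(Nc2ncc(Cl)c(Nc3ccccc3Cl)n2)cn1)NO` has the same atoms as compound 3, joined differently: 2-chlorophenyl in place of 4-chlorophenyl on a nitrogen on an aromatic ring. The closest measured precedent is a 1.2-fold lower number from compound 1 to compound 3 (0.07 log units; within the scatter), where 4-chlorophenyl replaces 3-chlorophenyl, and this step lies within the scatter. Two further steps, a 1.4-fold lower number from compound 1 to compound 2 (0.14 log units; within the scatter) and a 1.2-fold higher number from compound 2 to compound 3 (0.07 log units; within the scatter), also change only the aryl group on that nitrogen, and both stay within the scatter. Within the data shown here, no measured compound carries 2-chlorophenyl, so this group remains untested and the uncertainty is wider than these small steps alone suggest. On this evidence, no change beyond the scatter is expected in this assay, and the estimated step is a 1.1-fold higher number from compound 3 to compound 4 (0.03 log units; within the scatter). For compound 4 the expected value is 520 nM, with an estimated range of 250 nM to 1100 nM.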

Compound 4, half-maximal inhibitory concentration: 1810 nM
The estimate for compound 4 lay 3.5-fold (0.54 log units) below the measured number; measured number outside the range, above it.
By their numbers in this assay, from the lowest: compounds 2, 3 and 1 (each within the scatter of the next); then compound 4.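

In this assay, the position of the chlorine on the phenyl ring now matters: 2-chlorophenyl gives a 3.7-fold higher number from compound 3 to compound 4 (0.57 log units; beyond the scatter) in place of 4-chlorophenyl, whereas compound 1 and compound 3, with 3-chlorophenyl and 4-chlorophenyl, could not be told apart. The 2-chlorophenyl group also separates from the other two aryl groups, with a 4.3-fold higher number from compound 2 to compound 4 (0.63 log units; beyond the scatter) and a 3.1-fold higher number from compound 1 to compound 4 (0.49 log units; beyond the scatter) as the remaining steps, so among these four compounds it alone stands apart on this nitrogen. Nothing given here accounts for this difference.

Going by these compounds, whether the step belongs to chlorine itself stays open, and a 2-fluorophenyl or 2-methoxyphenyl group on the same nitrogen would bear on that. On these data alone, how a 2,6-dichlorophenyl group would behave also remains unknown.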